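This account rests on a few compounds, and the source may have more. Where it says the series, first, only, none or still open, it means among the compounds named here.

Compound 1 `O=C1COCCN1c1ccc(/N=C\c2cn(C(=O)c3ccccc3)c3ccccc23)cc1`: 87.3%
Compound 2 `O=C1COCCN1c1ccc(/N=C\c2cn(C(=O)c3ccc(Cl)cc3)c3ccccc23)cc1`: 93.7%
Compound 3 `O=C1COCCN1c1ccc(/N=C\c2cn(Cc3ccccc3)c3ccccc23)cc1`: 84%

In an ADME assay on BV-2 cells (Mus musculus) for cytotoxicity, read by MTT assay, with a stated time of 48 h, tested at 5 uM (a higher number here means a weaker effect of the compound at the concentration tested, a lower number a stronger effect), compound 3 carries the lowest of the three numbers, but the steps of a number 3.3 percentage points lower from compound 1 to compound 3 (within the scatter) and a number 9.7 percentage points lower from compound 2 to compound 3 (within the scatter) both lie within the scatter, so the three compounds cannot be separated. Compound 4 `O=C1COCCN1c1ccc(/N=C\c2cn(Cc3ccc(F)cc3)c3ccccc23)cc1` differs from compound 3 by fluoro in place of hydrogen on an aromatic carbon. Among the compounds with values here, the one measured step that bears on this change is a number 6.4 percentage points higher from compound 1 to compound 2 (within the scatter), which likewise brings a halogen onto a phenyl ring and stayed within the scatter. Compound 4 is therefore expected to show no step beyond the scatter, a number 2 percentage points higher from compound 3 to compound 4 (within the scatter). The estimate for compound 4 is 86%, with a range from 74% to 96%.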

Compound 4, a percentage reported as activity, at one concentration (the size of the read-out at that concentration, not a potency): 69.3%
Estimate against measurement, compound 4: 16.7 percentage points above, outside the stated range (below it).
By their numbers in this assay, from the lowest: compound 4; then compounds 3, 1 and 2 (each within the scatter of the next).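

In this assay, fluoro in place of hydrogen on an aromatic carbon of the benzyl group gives a step beyond the scatter, a number 14.7 percentage points lower from compound 3 to compound 4 (beyond the scatter), whereas the chloro change on the benzoyl group of compound 1 stayed within it. The 4-fluorobenzyl group also separates from both carbonyl-linked groups, with a number 18 percentage points lower from compound 1 to compound 4 (beyond the scatter) and a number 24.4 percentage points lower from compound 2 to compound 4 (beyond the scatter), although benzyl itself could not be separated from them. No measurement shown here accounts for this step. On these data alone, what chloro, methoxy or an amine at this place on the benzyl group would give remains open. So does whether fluoro on the benzoyl group of compound 1 would give a similar step.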